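Changing the ring on the sulfonyl of compound 2

This account rests on a few compounds, and the source may have more. Where it says the series, first, only, none or still open, it means among the compounds named here.

Going by the values given here, in a functional assay on DU-145 cells (Homo sapiens) for inhibition, read by trypan blue exclusion, with a stated time of 72 h (on this read-out lower numbers stand for stronger inhibition and higher numbers for weaker inhibition), compound 1 (`Cn1c(=O)c(C(=O)Nc2ccc(F)cc2)cc2cnc(Nc3ccc4[nH]ccc4c3)nc21`) gives 5000 nM and compound 2 (`Cn1c(=O)c(S(=O)(=O)c2ccc(Cl)cc2)cc2cnc(Nc3ccc4[nH]ccc4c3)nc21`) gives 250 nM and so holds the lower of the only two numbers so far. Compound 3 (`Cn1c(=O)c(S(=O)(=O)c2ccc(F)cc2[N+](=O)[O-])cc2cnc(Nc3ccc4[nH]ccc4c3)nc21`) has not yet been measured. It keeps the shared core and the sulfonyl of compound 2 but carries 4-fluoro-2-nitrophenyl in place of 4-chlorophenyl on the sulfonyl sulfur (4-fluoro-2-nitrophenyl in place of 4-chlorophenyl on a sulfonyl sulfur). Among the compounds with values here, the only measured step that bears on this is a 20-fold lower number from compound 1 to compound 2 (1.30 log units; beyond the scatter) and it is large, beyond the scatter. That step, however, exchanged (4-fluorophenyl)carbamoyl for (4-chlorophenyl)sulfonyl on an aromatic carbon, whereas compound 3 keeps the sulfonyl and changes only the ring attached to it. Within the data shown here, no measured pair shows what such a ring change does, so the size of that earlier step is not carried over. The expectation therefore starts from compound 2 at 250 nM and no step beyond the scatter is expected in this assay for this change. The estimate is a 1.2-fold higher number from compound 2 to compound 3 (0.08 log units; within the scatter) and it remains an expectation with wide uncertainty. For compound 3 the estimated value is 300 nM with an expected range of 90 nM to 1200 nM around it.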

Compound 3, half-maximal inhibitory concentration: 1500 nM
Compound 3: the middle estimate sits 5.0-fold (0.70 log units) below what was measured; the whole stated range lies below it.
By their numbers in this assay, from the lowest: compound 2; then compound 3; then compound 1.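

With the sulfonyl and the shared core held fixed, the ring on the sulfonyl sulfur still moves the result in this assay: there is a 6.0-fold higher number from compound 2 to compound 3 (0.78 log units; beyond the scatter) when 4-fluoro-2-nitrophenyl replaces 4-chlorophenyl. The earlier step exchanged the whole group on an aromatic carbon, so it could not separate the sulfonyl link from the ring it carries, whereas this pair shows that the sulfonyl does not set the number alone and that this ring swap costs inhibition beyond the usual scatter. No measurement shown here explains why the number rises, so the cause of this step stays unknown.

The entering ring differs from 4-chlorophenyl in two ways at once, in the fluorine that takes the place of chlorine and in the added nitro group, and these compounds cannot say how much of the step belongs to each. Rings such as plain phenyl, 4-fluorophenyl or 2-nitrophenyl on the same sulfonyl sulfur would divide the step between those two changes, and whether any ring gives a lower number than compound 2 remains open.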